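Methylation of the phenol in a pyrazole urea series

A few compounds are considered here, and "the series" means these few. Any claim that something is new, unique, unknown or untested is made for them only; others in the source may bear on it.

Compounds and values in a functional assay on OVCAR-4 cells (Homo sapiens) for inhibition, read by sulforhodamine B assay, with a stated time of 48 h, tested at 0.01 uM; on this read-out lower numbers stand for a stronger effect and higher numbers for a weaker effect at the one concentration tested:
compound 1 `O=C(Nc1cccc(-n2cc(-c3ccncc3)c(-c3cc(O)cc(Cl)c3)n2)c1)Nc1ccc(Cl)c(C(F)(F)F)c1`, 99%
compound 2 `O=C(Nc1cccc(-n2cc(-c3ccncc3)c(-c3cc(O)cc(Cl)c3)n2)c1)Nc1ccc(Cl)c(Cl)c1`, 108%

Going by the values given here, compound 1 gives the lowest of the two numbers in this assay, with compound 2 as its only neighbour, the difference between them lying within the scatter (a number 9 percentage points higher from compound 1 to compound 2 (within the scatter)). Neither value suggests a measurable effect at the concentration used. Compound 3 `COc1cc(Cl)cc(-c2nn(-c3cccc(NC(=O)Nc4ccc(Cl)c(C(F)(F)F)c4)c3)cc2-c2ccncc2)c1` differs from compound 1 in one place: methyl in place of hydrogen on an oxygen on an aromatic ring. Among the compounds with values here, no measured step touches this part of the molecule; the single step that exists, a number 9 percentage points higher from compound 1 to compound 2 (within the scatter), concerns the ring at the far end of the urea and was within the scatter. With both measured compounds sitting at essentially no effect in this assay, compound 3 is expected to behave the same way, and the estimated step of a number 1 percentage points higher from compound 1 to compound 3 (within the scatter) is none beyond the scatter. Compound 3 is therefore estimated at 100% in this assay, with a range from 85% to 115%.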

Compound 3, a percentage reported as activity, at one concentration (the size of the read-out at that concentration, not a potency): 99%
Beside the measured number, compound 3's estimate is 1 percentage points above it, within the range that was stated.
By their numbers in this assay, from the lowest: compounds 1, 3 and 2 (each within the scatter of the next).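

Going by these compounds alone, with this result the oxygen on the aromatic ring enters the series as a point of change for the first time: in this assay, hydroxy to methoxy, with 3-chloro-5-hydroxyphenyl becoming 3-chloro-5-methoxyphenyl, gives no change at the digits printed from compound 1 to compound 3 (within the scatter) and so leaves the read-out where it stood. Methyl on this oxygen therefore brings no measurable effect at this concentration, just as the earlier change at the far end of the urea brought none, but compound 1 already showed no effect, so the flat result cannot show whether the hydroxy hydrogen matters. No measurement shown here bears on the reason for this result.

The compounds shown leave open whether an amine or a carboxylic acid in place of the hydroxy, or a longer chain on the oxygen, would move the read-out. They also leave open whether hydroxy and methoxy would still match at a concentration where the series has a measurable effect.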